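Swapping phenyl for 3,4-dichlorophenyl on the amide carbonyl

The compounds below may be only part of what the source reports. "The series", "measured", "known", "first", "only" and "open" are said of these compounds alone.

The two measured compounds share a nitro-bearing aromatic core that carries a benzyl-type ether and an amide or sulfonamide nitrogen. Compound 1 `CC(C)c1ccc(COc2cc([N+](=O)[O-])ccc2NS(C)(=O)=O)cc1` carries a sulfonamide and, in an assay on SK-BR-3 cells for inhibition of Aromatase (Homo sapiens) (on this read-out lower numbers stand for stronger inhibition and higher numbers for weaker inhibition), compound 1 gives 7450 nM. Compound 2 `O=C(Nc1ccc([N+](=O)[O-])cc1OCc1ccccc1)c1ccccc1` carries a benzamide in place of the sulfonamide. In this assay compound 2 reaches only a limit, > 25000 nM, so its true value is not known as a number. That limit is the one sitting at the top of the range, (the limit of > 25000 nM in this assay, at which 1 of the 2 values shown sits), and it means compound 2 shows no inhibition that could be measured. Compound 3 `O=C(Nc1ccc([N+](=O)[O-])cc1OCc1ccccc1)c1ccc(Cl)c(Cl)c1` differs from compound 2 in one place: 3,4-dichlorophenyl in place of phenyl on a carbonyl carbon. Within the data shown here, no measured pair shows how such a change moves the read-out, so the expected size of the step from compound 2 to compound 3 rests on the limit alone. Compound 3 is expected to stay weak, with a step of an at least 1.2-fold lower number from compound 2 to compound 3 (0.09 log units; that floor lies within the scatter) that is as likely to sit within the scatter as beyond it. The estimate for compound 3 in this assay is 20000 nM, with a range from 6000 nM to 60000 nM, and a good chance that only a limit is reported again.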

Compound 3, half-maximal inhibitory concentration: > 25000 nM
Compound 3 ended at the assay's limit; the forecaster's own chance of this, stated with the estimate: 55%; at least 1.2-fold (0.09 log units) between middle value and limit.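

In this assay compound 3 gives > 25000 nM, which is a limit and not a number. Compound 2 also stands at a limit, so the step between compound 2 and compound 3 cannot be read: the limit of > 25000 nM in this assay, at which 2 of the 3 values shown sit.

As far as these compounds go, whether 3,4-dichlorophenyl in place of phenyl on a carbonyl carbon changes the inhibition at all, and by how much, stays open.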